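Aryl exchange from compound 3 to compound 4

The source may report more compounds than this note shows. Statements on the series, on what has been measured and on what is new or still open speak of the compounds shown alone.

In an ADME assay on microsomes from liver (Canis lupus familiaris) for metabolic stability (a lower number here means that the compound disappears faster, a higher number that the compound lasts longer), compound 1 (`FC(F)(F)c1ccc(NCCNc2ncc(-c3ncc[nH]3)c(-c3ccc(Cl)cc3Cl)n2)nc1`) gives > 0.5 h as a limit and not a number. Compound 2 (`Clc1ccc(-c2nc(NCCNc3ccccn3)ncc2-c2ncc[nH]2)c(Cl)c1`) gives > 0.5 h as a limit as well. Compound 3 (`Nc1nc(NCCNc2ncc(-c3ncc[nH]3)c(-c3ccc(C(F)(F)F)cc3)n2)ccc1[N+](=O)[O-]`) gives > 0.5 h as a limit too, so it stands at that limit and nothing finer can be said of it. The three compounds share the limit of > 0.5 h in this assay, at which 3 of the 3 values shown sit, and no half-life has yet been read as a number.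

Compound 4 (`Nc1nc(NCCNc2ncc(-c3ncc[nH]3)c(-c3cc(F)c(F)cc3F)n2)ccc1[N+](=O)[O-]`) departs from compound 3 by one exchange, 2,4,5-trifluorophenyl in place of 4-(trifluoromethyl)phenyl on an aromatic carbon (2,4,5-trifluorophenyl in place of 4-(trifluoromethyl)phenyl on an aromatic carbon, ortho to a 1H-imidazol-2-yl group).

Among the compounds with values here, the only measured step is a step that the two limits leave unreadable from compound 1 to compound 2 and it is a different exchange, hydrogen in place of trifluoromethyl, so it lends no size to this one. No step beyond the scatter is therefore expected in this assay and no direction can be named. The estimated step is a step that the limit leaves unreadable from compound 3 to compound 4 and it remains an expectation without a measured anchor. The expectation leans on compound 3 at > 0.5 h as a limit, so a report at that same limit is the likeliest outcome for compound 4. In this assay compound 4 is estimated at 0.8 h with 0.4 h to 1.6 h as the expected range.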

Compound 4, half-life: > 0.5 h
Compound 4: a limit, no number; the forecaster's own chance of this, stated with the estimate: 70%; the middle value is on the limit's open side.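

The step from compound 3 to compound 4 in this assay cannot be read, as both compounds give a limit and not a number: the limit of > 0.5 h in this assay, at which 4 of the 4 values shown sit.

The compounds shown leave open whether 2,4,5-trifluorophenyl and 4-(trifluoromethyl)phenyl differ at all in this assay once half-lives can be read as numbers.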